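Acid tail exchange on the aryl isoxazole series

The compounds below may be only part of what the source reports. "The series", "measured", "known", "first", "only" and "open" are said of these compounds alone.

Measured compounds:
compound 1 `CC(C)c1onc(-c2ccccc2)c1COc1ccc(CCCC(=O)O)cc1` — 31000 nM
compound 2 `Cc1cccc(C)c1-c1noc(C(C)C)c1COc1ccc(CCCC(=O)O)cc1` — 7700 nM
compound 3 `CC(C)c1onc(-c2c(Cl)cccc2Cl)c1COc1ccc(CCCC(=O)O)cc1` — 6000 nM

All three numbers come from an assay on HEK-293T cells for activation of Bile acid receptor (Homo sapiens), read by a luciferase reporter, with a stated time of 14 h; a lower number here means that less compound is needed, a higher number that more compound is needed for the effect. Compound 1 stands highest of the three: the step of a 4.0-fold lower number from compound 1 to compound 2 (0.60 log units; beyond the scatter) and the step of a 5.2-fold lower number from compound 1 to compound 3 (0.71 log units; beyond the scatter) both lie beyond the scatter, while compounds 2 and 3 sit within the scatter of each other a 1.3-fold lower number from compound 2 to compound 3 (0.11 log units; within the scatter).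

Compound 4 `CC(C)c1onc(-c2ccccc2)c1COc1ccc(COc2ccc(CC(=O)O)cc2)cc1` is not yet measured in this assay. It differs from compound 1 in a single place: 4-(carboxymethyl)phenoxy in place of 2-carboxyethyl on a saturated chain carbon bound to an aromatic carbon. Among the compounds with values here, the two measured steps both alter the aryl group on the core of compound 1 and leave the acid tail untouched, so neither bears on this change; there is no measured step that tests the acid tail. The expectation for compound 4 therefore rests on compound 1 alone, and the step of a 2.1-fold lower number from compound 1 to compound 4 (0.32 log units; beyond the scatter) is given as an estimate with wide bounds rather than a directional call. Compound 4 is expected to give about 15000 nM, within 3000 nM to 60000 nM.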

Compound 4, half-maximal effective concentration: 11000 nM
Beside the measured number, compound 4's estimate is 1.4-fold (0.13 log units) above it, and the stated range covers the measured number.
By their numbers in this assay, from the lowest: compounds 3, 2 and 4 (each within the scatter of the next); then compound 1.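

The earlier steps shown here all altered the aryl group on the shared core, so this is the only measured read on the acid tail in this assay. Exchanging 2-carboxyethyl for 4-(carboxymethyl)phenoxy, with the carboxylic acid kept and a six-membered aromatic ring added to the tail, gives a 2.8-fold lower number from compound 1 to compound 4 (0.45 log units; beyond the scatter), so the number responds to this place as well as to the aryl group. No measurement at hand accounts for this step.

Within the data shown here, the single exchange alters the tail's length, its aromatic ring and its oxygen together, leaving open which of these carries the step. Also open, on these data alone, are whether the step would carry over to the 2,6-dichlorophenyl or 2,6-dimethylphenyl compounds, and how an amine or a longer chain would read at this place.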